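A halogenated benzyl ether on a shared oxime core

A few compounds are considered here, and "the series" means these few. Any claim that something is new, unique, unknown or untested is made for them only; others in the source may bear on it.

Compound 1 `O=[N+]([O-])c1ccc2c(c1)/C(=N\O)C(c1c[nH]c3ccc([N+](=O)[O-])cc13)=N2` gives 11500 nM in a functional assay on NCI-H460 cells (Homo sapiens) for cytotoxicity, read by MTT assay, with a stated time of 2 days; a higher number here means a weaker inhibitor, a lower number a stronger inhibitor. Compound 2 `c1ccc(CO/N=C2/C(c3c[nH]c4ccccc34)=Nc3ccccc32)cc1` gives 22000 nM in this assay. Compound 3 `Cc1ccc(CO/N=C2/C(c3c[nH]c4ccc(F)cc34)=Nc3ccc(F)cc32)cc1` gives 12000 nM in this assay. Compound 2 carries the highest number of the three, but its gap to compound 3 and its gap to compound 1 both lie within the scatter of repeated measurements, so the three compounds cannot be placed in an order. Compound 4 `Fc1ccc(CO/N=C2/C(c3c[nH]c4ccccc34)=Nc3ccccc32)c(Cl)c1` differs from compound 2 by 2-chloro-4-fluorophenyl in place of phenyl on a saturated chain carbon bound to an oxygen on an unsaturated carbon. Among the measured compounds shown here, no pair of measured compounds differs in only this place, so no measured step is available to lean on; the three numbers in hand sit close together, and nothing in them suggests that a change on the benzyl group moves the number far. The step is therefore expected to be small, a 1.5-fold lower number from compound 2 to compound 4 (0.17 log units; within the scatter), and not beyond the scatter in either direction. Compound 4 is expected to give 15000 nM in this assay, with a range from 6000 nM to 40000 nM.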

Compound 4, half-maximal inhibitory concentration: 21900 nM
Beside the measured number, compound 4's estimate is 1.5-fold (0.16 log units) below it; low and high end bracket the measured number.
By their numbers in this assay, from the lowest: compounds 1, 3, 4 and 2 (each within the scatter of the next).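

Benzyl to 2-chloro-4-fluorobenzyl is the first single change in this series that can be read on its own: in this assay it comes to a 1.0-fold lower number from compound 2 to compound 4 (0.00 log units; within the scatter). On the core of compound 2, the two numbers therefore cannot be told apart, and this position takes on both a chlorine and a fluorine on its phenyl ring without a measurable step. Nothing measured here speaks to the reason for this outcome.

The compounds shown leave open whether the same holds on the cores of compound 1 and compound 3, since the 2-chloro-4-fluorobenzyl group appears here on one core only. Also open, on these data alone, is what an amine or a carboxylic acid on the phenyl ring, or a longer chain in place of the benzyl group, would do at this place.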